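The source may report more compounds than this note shows. Statements on the series, on what has been measured and on what is new or still open speak of the compounds shown alone.

Compound 2 `O=C(O)C1=Cc2ccccc2OC1(OCc1cc(-c2ccc([N+](=O)[O-])cc2)no1)C(F)(F)F` was examined in a functional assay on MCF7 cells (Homo sapiens) for inhibition, read by MTT assay, with a stated time of 24 h; a higher number here means a weaker inhibitor, a lower number a stronger inhibitor. In this assay compound 2 reaches only a limit, > 150000 nM. Compound 3 `CCOC(=O)C1=Cc2ccccc2OC1(OCc1cc(-c2ccc([N+](=O)[O-])cc2)no1)C(F)(F)F`, which carries ethyl in place of hydrogen on an oxygen next to a carbonyl group, likewise stops at a limit in this assay, > 150000 nM. The step that the two limits leave unreadable from compound 2 to compound 3 is therefore not readable. Compound 1 `CCOC(=O)C1=Cc2ccccc2OC1(OCc1cn(CC(=O)Nc2ccccc2Br)nn1)C(F)(F)F` also gives only a limit in this assay, > 150000 nM. The shared picture is the limit of > 150000 nM in this assay, at which 3 of the 3 values shown sit. Compound 4 `Cc1ccc(-c2cc(COC3(C(F)(F)F)Oc4ccccc4C=C3C(=O)O)on2)cc1` differs from compound 2 by methyl in place of nitro on an aromatic carbon. Among the measured compounds shown here, no measured step bears on this change, and the limits give no direction. Compound 4 is therefore expected near 150000 nM, within 50000 nM to 300000 nM. The expected step of a number no higher from compound 2 to compound 4 (the limit leaves the size open) is estimated to be none beyond the scatter.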

Compound 4, half-maximal inhibitory concentration: 30100 nM
Beside the measured number, compound 4's estimate is 5.0-fold (0.70 log units) above it; measured number below the stated range.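

In this assay, 4-methylphenyl in place of 4-nitrophenyl gives an at least 4.9-fold lower number from compound 2 to compound 4 (0.69 log units; beyond the scatter), so the group at this position can move the number on this core. Among the compounds shown here, the earlier step, with ethyl on the acid oxygen, cannot be read, and no earlier compound gave a number. Compound 4 alone comes off the limit of the assay: the limit of > 150000 nM in this assay, at which 3 of the 4 values shown sit.

As far as these compounds go, whether the step comes from losing nitro or from gaining methyl stays open, since one pair cannot separate the two. Also open, from the compounds shown here alone, are how an amine or a methoxy group would read at this position, and whether the ethyl ester of compound 4 would keep its number.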